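Pyrazine in place of pyridine on the amide carbonyl

This account rests on a few compounds, and the source may have more. Where it says the series, first, only, none or still open, it means among the compounds named here.

Within the data shown here, compound 2 `COc1ccc(Cn2c(CCc3ccccc3)nnc2[C@H](NC(=O)c2ccncc2)c2c[nH]c3ccccc23)c(OC)c1` gives 93 nM in a functional assay on CHO cells for antagonist activity at growth hormone secretagogue receptor type 1 (Homo sapiens) (on this read-out lower numbers stand for stronger inhibition and higher numbers for weaker inhibition), the higher of the two numbers measured so far. Compound 1 `COc1ccc(Cn2c(CCc3ccccc3)nnc2[C@H](NC(=O)c2ccccn2)c2c[nH]c3ccccc23)c(OC)c1`, which carries pyridin-2-yl on the carbonyl carbon, gives 25 nM; the step of a 3.7-fold higher number from compound 1 to compound 2 (0.57 log units; beyond the scatter) is the only one measured. Compound 3 `COc1ccc(Cn2c(CCc3ccccc3)nnc2[C@H](NC(=O)c2cnccn2)c2c[nH]c3ccccc23)c(OC)c1` differs from compound 2 by pyrazin-2-yl in place of pyridin-4-yl on a carbonyl carbon. Among the measured compounds shown here, no step with pyrazin-2-yl has been measured; the step from pyridin-2-yl to pyridin-4-yl is the only one that bears on it. Pyrazin-2-yl carries one of its two nitrogens in the same ring position as pyridin-2-yl, so the move is expected to take part of that step back. Compound 3 is expected at 40 nM, with a range of 15 nM to 110 nM, which means an expected step of a 2.3-fold lower number from compound 2 to compound 3 (0.37 log units; beyond the scatter).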

Compound 3, antagonist equilibrium constant: 24 nM
Estimate against measurement, compound 3: 1.7-fold (0.22 log units) above; low and high end bracket the measured number.
By their numbers in this assay, from the lowest: compounds 3 and 1 (each within the scatter of the next); then compound 2.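

In this assay, the change from pyridin-4-yl to pyrazin-2-yl on the carbonyl carbon gives a 3.9-fold lower number from compound 2 to compound 3 (0.59 log units; beyond the scatter) and the change from pyridin-2-yl to pyrazin-2-yl gives a 1.0-fold lower number from compound 1 to compound 3 (0.02 log units; within the scatter), so this position accepts pyrazin-2-yl as well as it accepts pyridin-2-yl. The count of ring hetero atoms does not order the series: compound 1 and compound 2 each carry one yet are separated by a step beyond the scatter, while compound 1 and compound 3 carry different counts and are not. Nothing at hand accounts for why pyridin-4-yl stands apart from the other two rings.

Phenyl and pyridin-3-yl on the same carbonyl carbon would show whether a ring nitrogen is needed here at all, and which placement of it counts. From the compounds shown here alone, whether an amino or methoxy group on the pyrazin-2-yl ring is accepted also remains open.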